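Lipophilicity notes: inverting one chain stereocentre

The source may hold more compounds than are shown below. What is called first, only, known or untested is meant among the compounds shown, and "the series" means these compounds.

compound 1 `Cc1cn([C@H]2CCCN([C@@H](CC(C)C)c3ccc(C(=O)O)c(Oc4cccc(Cl)c4)c3F)C2)c(=O)[nH]c1=O`: 0.57
compound 2 `CC[C@@H](c1ccc(C(=O)O)c(Oc2cccc(Cl)c2)c1)N1CCC[C@H](n2cc(C)c(=O)[nH]c2=O)C1`: 0.22

In a physicochemical assay for lipophilicity, using the shake flask method, in phosphate buffer, measured as octanol-water partition, at pH 7.4 (on this read-out lower numbers stand for lower lipophilicity and higher numbers for higher lipophilicity), compound 2 gives 0.22, the lowest of the two numbers. Compound 1 gives 0.57, higher by an amount beyond the scatter. Among the measured compounds shown here, compound 3 `CC[C@H](c1ccc(C(=O)O)c(Oc2cccc(Cl)c2)c1)N1CCC[C@H](n2cc(C)c(=O)[nH]c2=O)C1` has not been measured. the two compounds have the same atoms and bonds and differ only in configuration as drawn: 1 of 2 stereo elements differ; a stereocentre at a saturated chain carbon is drawn S in compound 2 and R in compound 3 No pair of measured compounds shows a step of this kind, and the change adds and removes nothing. The step is therefore expected to be small, no change at the digits printed from compound 2 to compound 3 (within the scatter), with no direction beyond the scatter. Compound 3 is expected to give about 0.22, within -0.05 to 0.5.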

Compound 3, distribution coefficient: 0.22
Estimate against measurement, compound 3: no gap at the digits printed, and the stated range covers the measured number.
By their numbers in this assay, from the lowest: compounds 2 and 3 (each within the scatter of the next); then compound 1.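

In this assay, inverting the stereocentre at the saturated chain carbon from S to R gives no change at the digits printed from compound 2 to compound 3 (within the scatter). Among the compounds shown here, this is the first reading of configuration at this carbon, as compound 1 and compound 2 differ in more than one place and give no step. The comparison isolates this one centre: the fact that compounds 2 and 3 differ only in the configuration as drawn

As far as these compounds go, whether configuration at this carbon would matter as little with an amide in place of the carboxylic acid remains open. From the compounds shown here alone, the effect of inverting the second stereocentre on this read-out is also open.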